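From isopropyl to formyl on the shared core

The source may hold more compounds than are shown below. What is called first, only, known or untested is meant among the compounds shown, and "the series" means these compounds.

In a toxicity assay on CCRF-CEM cells (Homo sapiens) for cytotoxicity (on this read-out higher numbers stand for lower toxicity in this test and lower numbers for higher toxicity in this test), compound 1 `Fc1cccc(F)c1Cn1c(-c2c(F)cccc2F)nc2c(Cl)cccc21` gives 30.4 uM and compound 2 `CC(C)c1cccc2c1nc(-c1c(F)cccc1F)n2Cc1c(F)cccc1F` gives 27 uM. Within the data shown here, compound 2 therefore stands level with compound 1, the only other measured compound, and the two numbers cannot be told apart.

The next compound is compound 3 `O=Cc1cccc2c1nc(-c1c(F)cccc1F)n2Cc1c(F)cccc1F`, with formyl in place of isopropyl on an aromatic carbon. Among the measured compounds shown here, only one measured step bears on this change. It exchanged chloro for isopropyl on an aromatic carbon, and a 1.1-fold lower number from compound 1 to compound 2 (0.05 log units; within the scatter) stays within the scatter. Neither measured compound carries formyl, so the data do not test this group directly, and one small step is thin support.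

For the measured compounds named here, with compound 1 and compound 2 as the only guide, no step beyond the scatter is expected in this assay, and no firm direction can be assigned. The expected change is a 1.1-fold lower number from compound 2 to compound 3 (0.03 log units; within the scatter). For compound 3 the estimated value is 25 uM, with an expected range from 10 uM to 55 uM.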

Compound 3, half-maximal toxic concentration: 0.82 uM
Compound 3: middle estimate off by 30-fold (1.48 log units), on the high side; the measured number lies below the stated range.
By their numbers in this assay, from the lowest: compound 3; then compounds 2 and 1 (each within the scatter of the next).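

In this assay this position is not indifferent to its substituent: formyl in place of isopropyl gives a 33-fold lower number from compound 2 to compound 3 (1.52 log units; beyond the scatter) and formyl in place of chloro gives a 37-fold lower number from compound 1 to compound 3 (1.57 log units; beyond the scatter) with higher toxicity in this test in both comparisons. Chloro and isopropyl could not be told apart here, so the level reading of the earlier pair holds for those two groups only and does not extend to every group on this aromatic carbon. Of the three groups, only formyl brings an oxygen, a double bond outside aromatic rings and a hydrogen-bond acceptor, but three compounds cannot show which of these features, if any, goes with the lower number, and no measurement at hand offers an explanation for the shift.

Still open, as far as these compounds go, is whether the lower number belongs to formyl alone or also appears with acetyl, hydroxymethyl, a carboxylic acid or an amine on this aromatic carbon. With only these cells shown, it also remains open whether compound 3 keeps its lower number on other cell types.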